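Replacing a hydroxymethyl-ethyl arm with a dimethylisoxazole

The compounds below may be only part of what the source reports. "The series", "measured", "known", "first", "only" and "open" are said of these compounds alone.

Compound 3 `Cc1cc(C)c(CN2CCc3c(Cl)cc([C@@H](C)CO)c(Cl)c3C2=O)c(=O)[nH]1` gives 260 nM in an assay for inhibition of histone-lysine N-methyltransferase EZH2 variant Y641N (Homo sapiens), read by scintillation counting, with a stated time of 60 min, in the presence of a further agent that is not named here (a higher number here means a weaker inhibitor, a lower number a stronger inhibitor), the lower of the two single numbers seen on this shared core. Compound 1 `Cc1cc(C)c(CN2CCc3c(Cl)cc([C@@H](CO)[C@@H]4CCOC4)c(Cl)c3C2=O)c(=O)[nH]1`, which carries a tetrahydrofuranyl-substituted arm at the same position, gives 1260 nM, and the step of a 4.8-fold lower number from compound 1 to compound 3 (0.69 log units; beyond the scatter) shows that trimming that arm helps. Compound 2 `CCOC(c1cc(Cl)c2c(c1Cl)C(=O)N(Cc1c(C)cc(C)[nH]c1=O)CC2)C1CS(=O)(=O)C1` gives 460 nM; 2.9 nM (2 entries); these entries are far apart (the several entries of compound 2 in this assay, 460 nM; 2.9 nM (2 entries)), so it offers no single number for comparison.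

Compound 4 `Cc1cc(C)c(CN2CCc3c(Cl)cc(-c4c(C)noc4C)c(Cl)c3C2=O)c(=O)[nH]1` differs from compound 3 by 3,5-dimethyl-1,2-oxazol-4-yl in place of 1-(hydroxymethyl)ethyl on an aromatic carbon. Among the measured compounds shown here, no measured step changes this position to an aromatic ring, so the step from compound 1 to compound 3 bears only loosely on it: it shows that the site tolerates a change of group size without loss. A step of modest size in the direction of a lower number is therefore expected, a 2.4-fold lower number from compound 3 to compound 4 (0.37 log units; beyond the scatter), with wide uncertainty. For compound 4 the estimate in this assay is 110 nM, expected to lie between 15 nM and 700 nM.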

Compound 4, inhibition constant: 1.15 nM
Beside the measured number, compound 4's estimate is 96-fold (1.98 log units) above it; measured number below the stated range.
By their numbers in this assay, from the lowest: compound 4; then compound 3; then compound 1.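

In this assay, 3,5-dimethyl-1,2-oxazol-4-yl in place of 1-(hydroxymethyl)ethyl gives a 230-fold lower number from compound 3 to compound 4 (2.35 log units; beyond the scatter), which shows that this aromatic carbon, ortho to a chloro group, can carry a five-membered aromatic ring with a very large gain. Heavy-atom count alone does not order these values, since the entering ring is close in size to the tetrahydrofuranyl-bearing arm and still gives a 1100-fold lower number from compound 1 to compound 4 (3.04 log units; beyond the scatter). Nothing measured here accounts for the size of this gain.

As far as these compounds go, whether the gain belongs to the aromatic ring itself or to its two methyl groups remains open. Also open, from the compounds shown here alone, is what a phenyl ring, a pyridine or a 1,2-oxazole without those methyl groups would give at this carbon.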